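This account rests on a few compounds, and the source may have more. Where it says the series, first, only, none or still open, it means among the compounds named here.

Measured so far:
compound 1 `CC1CN(c2nc(NCc3ccc(C(=O)Nc4ccc(F)cc4)cc3)c3ccccc3n2)CCN1`: 2800 nM
compound 2 `Cc1ccc2nc(N(C)C)nc(NCc3ccc(C(=O)Nc4ccc(Cl)nc4)cc3)c2c1`: 1300 nM

In a functional assay on HCT-116 cells (Homo sapiens) for inhibition, read by luminescence and resazurin assay, with a stated time of 3 days (a higher number here means a weaker inhibitor, a lower number a stronger inhibitor), compound 1 gives 2800 nM, the higher of the two numbers, while compound 2 gives 1300 nM, a gap beyond the usual scatter. Compound 3 `CCNc1nc(NCc2ccc(C(=O)Nc3ccc(F)cc3)cc2)c2ccccc2n1` has not been measured. It differs from compound 1 in one place: ethylamino in place of 3-methylpiperazin-1-yl on an aromatic carbon. Among the measured compounds shown here, no measured pair shows this change on its own, so its effect is not known from these data. The change is expected to move the number little, at most a slight lowering, within the scatter. Compound 3 is therefore estimated at about 2000 nM, between 600 nM and 6000 nM, an expected step of a 1.4-fold lower number from compound 1 to compound 3 (0.15 log units; within the scatter).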

Compound 3, half-maximal inhibitory concentration: 1900 nM
Beside the measured number, compound 3's estimate is 1.1-fold (0.02 log units) above it, and the stated range covers the measured number.
By their numbers in this assay, from the lowest: compounds 2, 3 and 1 (each within the scatter of the next, the first and the last beyond it).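

In this assay, putting ethylamino in place of 3-methylpiperazin-1-yl on the aromatic carbon between two ring nitrogen atoms gives a 1.5-fold lower number from compound 1 to compound 3 (0.17 log units; within the scatter). So this position accepts an open chain with no ring in place of the six-membered non-aromatic ring, without a change beyond the scatter. Nothing available explains why this swap changes so little.

As far as these compounds go, whether a carboxylic acid or a longer chain such as hexylamino would also leave the number in this range stays open. So does whether a simple morpholine ring would.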